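The compounds below may be only part of what the source reports. "The series", "measured", "known", "first", "only" and "open" are said of these compounds alone.

Working notes on the series, all on the shared core. Among the measured compounds shown here, in a functional assay on MCF7 cells (Homo sapiens) for cytotoxicity, read by WST assay, with a stated time of 72 h (on this read-out higher numbers stand for weaker inhibition and lower numbers for stronger inhibition), compound 3 (`O=C1Nc2c(ccc(F)c2F)C1(c1ccncc1)c1ccc(O)cc1`) gives 37 nM, the lowest number so far. The nearest value belongs to compound 1 (`CCCOc1ccc(C2(c3ccc(O)cc3)C(=O)Nc3c2ccc(F)c3F)cc1`), at 356 nM. Compound 2 (`CCCCCOc1ccc(C2(c3ccc(O)cc3)C(=O)Nc3c2ccc(F)c3F)cc1`) reads > 1000 nM, which is a limit of the assay and not a number.

The next compound is compound 4 (`O=C1Nc2c(ccc(F)c2F)C1(Cc1ccccc1)c1ccc(O)cc1`), still unmeasured. Its change from compound 3 is benzyl in place of pyridin-4-yl on a saturated ring carbon, which puts benzyl in place of pyridin-4-yl on a saturated ring carbon.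

For the measured compounds named here, the only measured step is an at least 2.8-fold higher number from compound 1 to compound 2 (0.44 log units; beyond the scatter). Going by the values given here, it bears on this change only indirectly, since neither compound 1 nor compound 2 carries pyridin-4-yl and no measured step swaps that group. Among the compounds with values here, it shows only that a change in a carbon chain can move the number in this assay beyond the scatter. The more useful comparison is between values: compound 3, with pyridin-4-yl, gives 37 nM, while compound 1, without that group, gives 356 nM. On that basis, a moderate move towards a higher number, meaning weaker inhibition, is expected, though with low confidence.

The expected change is a 4.1-fold higher number from compound 3 to compound 4 (0.61 log units; beyond the scatter). The estimated value for compound 4 is 150 nM, with an expected range from 40 nM to 600 nM.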

Compound 4, half-maximal inhibitory concentration: > 1000 nM
Compound 4 was reported as a limit (the forecaster's own chance of this, stated with the estimate: 10%); at least 6.6-fold (0.82 log units) between middle value and limit.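

In this assay, among the compounds shown here, the first measured change on the saturated ring carbon, two ring bonds from the ring nitrogen, gives an at least 27-fold higher number from compound 3 to compound 4 (1.43 log units; beyond the scatter) and is large, so the group at this carbon can decide the read-out on the shared core. The earlier step concerned only a saturated chain carbon and said nothing about this ring carbon, while the present one ties the lowest number in the series to pyridin-4-yl against benzyl in this one matched pair. The printed size of the step is only a lower bound, as compound 4 reads as a limit and not a number, as does compound 2: the limit of > 1000 nM in this assay, at which 2 of the 4 values shown sit.

The swap changes two things together, since pyridin-4-yl carries a ring nitrogen and a hydrogen-bond acceptor while benzyl has neither and has a carbon more, so the pair cannot tell which of these differences goes with the loss. Phenyl or pyridin-4-ylmethyl at this carbon would separate them, and pyridin-3-yl would test whether the place of the ring nitrogen matters.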